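The compounds below may be only part of what the source reports. "The series", "measured", "known", "first", "only" and "open" are said of these compounds alone.

Compound 1 `Nc1cc(N)c2nc(-c3ccccc3)c(NCc3ccc(Cl)c(Cl)c3)nc2c1` and compound 2 `COc1ccc(CNc2nc3cc(N)cc(N)c3nc2-c2ccccc2)cc1OC` share one core and differ only in the ring on the saturated chain carbon. In a functional assay on OVCAR-3 cells (Homo sapiens) for inhibition, read by sulforhodamine B assay, with a stated time of 48 h (on this read-out lower numbers stand for higher toxicity in this test and higher numbers for lower toxicity in this test), compound 1 gives 31600 nM, while compound 2 gives 8510 nM, the lowest of the two numbers; the change is a 3.7-fold lower number from compound 1 to compound 2 (0.57 log units; beyond the scatter). Compound 3 `COc1cc(CNc2nc3cc(N)cc(N)c3nc2-c2ccccc2)cc(OC)c1OC` carries methoxy in place of hydrogen on an aromatic carbon. For the measured compounds named here, no measured step shows the effect of adding a methoxy to an already present methoxy pattern, so the earlier step offers only weak guidance, and a step within the scatter is expected, namely a 1.1-fold lower number from compound 2 to compound 3 (0.03 log units; within the scatter). For compound 3 the estimate in this assay is 8000 nM, within 3000 nM to 20000 nM.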

Compound 3, concentration lethal to 50% of the cells: 18200 nM
Beside the measured number, compound 3's estimate is 2.3-fold (0.36 log units) below it, and the stated range covers the measured number.
By their numbers in this assay, from the lowest: compound 2; then compounds 3 and 1 (each within the scatter of the next).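

In this assay, placing a methoxy on this aromatic carbon, ortho to a methoxy group, gives a 2.1-fold higher number from compound 2 to compound 3 (0.33 log units; beyond the scatter), which means lower toxicity in this test. Adding methoxy to this ring therefore does not simply lower the number, as the replacement of the chlorines by methoxy groups alone might have suggested. No measurement shown here accounts for this rise.

The compounds shown leave open whether a hydroxyl or an ethoxy on the same carbon would also raise the number. They also leave open whether a chlorine there would do so.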